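Trimming the piperazine substituent to cyclopropylmethyl

This account rests on a few compounds, and the source may have more. Where it says the series, first, only, none or still open, it means among the compounds named here.

Measured compounds:
compound 1 `N#Cc1ccccc1COc1ccc(-c2cc(CN3CCN(Cc4ccc(C(F)(F)F)cc4)CC3)no2)cc1` — 5000 nM
compound 2 `COc1ccccc1COc1ccc(-c2cc(CN3CCN(Cc4ccc(C(F)(F)F)cc4)CC3)no2)cc1` — 900 nM
compound 3 `N#Cc1cccc(COc2ccc(-c3cc(CN4CCN(c5ccc(C(F)(F)F)cn5)CC4)no3)cc2)c1` — 1700 nM

In a functional assay on Huh-7 cells (Homo sapiens) for antiproliferative activity, read by sulforhodamine B assay, with a stated time of 72 h (on this read-out higher numbers stand for weaker inhibition and lower numbers for stronger inhibition), compound 3 gives 1700 nM, the second highest of the three numbers. Its nearest neighbour is compound 2, which gives 900 nM, a gap that stays within the scatter; compound 1, with 5000 nM, sits furthest away, beyond the scatter. Among the measured compounds shown here, the only single-point step among the measured compounds, a 5.6-fold lower number from compound 1 to compound 2 (0.74 log units; beyond the scatter), concerns the substituent on the benzyl ether at the far end of the shared core and does not touch the piperazine nitrogen.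

Compound 4 `N#Cc1cccc(COc2ccc(-c3cc(CN4CCN(CC5CC5)CC4)no3)cc2)c1` differs from compound 3 at that nitrogen: cyclopropylmethyl in place of 5-(trifluoromethyl)pyridin-2-yl on an amine nitrogen in a ring. For the measured compounds named here, no measured pair shows what happens when the aryl group on the piperazine is exchanged for a small saturated fragment, so the measured steps give no direct guide. With 5-(trifluoromethyl)pyridin-2-yl leaving and cyclopropylmethyl entering, the expectation is a move toward a higher number in this assay, of uncertain size. The estimated step is a 2.4-fold higher number from compound 3 to compound 4 (0.37 log units; beyond the scatter). Compound 4 is therefore expected to give about 4000 nM, within a range from 1500 nM to 12000 nM.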

Compound 4, half-maximal inhibitory concentration: 2900 nM
For compound 4 the middle estimate is 1.4-fold (0.14 log units) above the measured one; the measured number falls inside the stated range.
By their numbers in this assay, from the lowest: compounds 2, 3, 4 and 1 (each within the scatter of the next, the first and the last beyond it).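

This is the first step among the compounds shown that changes the amine nitrogen in the ring: in this assay, cyclopropylmethyl in place of 5-(trifluoromethyl)pyridin-2-yl gives a 1.7-fold higher number from compound 3 to compound 4 (0.23 log units; within the scatter), so the two compounds cannot be told apart on this read-out. In this one pair, a group of 4 heavy atoms with a three-membered ring of carbon only stands in for one of 10 heavy atoms with a six-membered aromatic ring, and the number stays within the scatter, so the aromatic ring and its trifluoromethyl are not required at this nitrogen to keep the number of compound 3. No measurement on hand explains this outcome.

The compounds shown leave open whether other groups on this nitrogen, such as a hydrogen, an acetyl group or a longer chain like n-butyl, would also stay within the scatter of compound 4. From the compounds shown here alone, it also remains open whether methoxy in place of cyano on an aromatic carbon, which gave a 5.6-fold lower number from compound 1 to compound 2 (0.74 log units; beyond the scatter), would have a similar effect with cyclopropylmethyl on the nitrogen.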